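This account rests on a few compounds, and the source may have more. Where it says the series, first, only, none or still open, it means among the compounds named here.

In a functional assay on T47D cells (Homo sapiens) for inhibition, read by CCK-8 assay, with a stated time of 72 h, tested at 10 uM (a higher number here means more inhibition of growth at the concentration tested, a lower number less inhibition of growth), compound 2 (`Cc1cccc(NC(=O)C2(C(=O)Nc3ccc(Nc4ncc5cc(C(=O)N(C)C)n(C6CCCC6)c5n4)cc3)CC2)c1`) gives 95.3%. This value lies within the scatter of compound 1 (`CN(C)C(=O)c1cc2cnc(Nc3ccc(NC(=O)C4(C(=O)Nc5ccc(F)cc5)CC4)cc3)nc2n1C1CCCC1`), which gives 105%. Compound 3 (`CN(C)C(=O)c1cc2cnc(Nc3ccc(N)cn3)nc2n1C1CCCC1`) gives 61.1%, a number beyond the scatter of the value for compound 2. Compound 4 (`CN(C)C(=O)c1cc2cnc(Nc3ccc(NC(=O)C4(C(=O)Nc5ccc(Cl)cc5)CC4)cc3)nc2n1C1CCCC1`) has not yet been measured. Its structure departs from that of compound 2 in one place: 4-chlorophenyl in place of 3-methylphenyl on an amide-type nitrogen. In plain terms, 4-chlorophenyl stands in place of 3-methylphenyl on an amide-type nitrogen. Within the data shown here, only one measured step involves a change at this place, the exchange of 4-fluorophenyl for 3-methylphenyl, and it reads a number 9.7 percentage points lower from compound 1 to compound 2 (within the scatter). On the evidence of that single step, which links compound 1 to compound 2, no change beyond the scatter is expected in this assay. Among the measured compounds shown here, no measured compound yet carries 4-chlorophenyl, so this expectation rests on that one comparison. The expected step is a number 1.7 percentage points higher from compound 2 to compound 4 (within the scatter). Compound 4 is estimated to give 97%, with an expected range from 85% to 108%.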

Compound 4, percent growth inhibition at one concentration: 95%
Beside the measured number, compound 4's estimate is 2 percentage points above it, within the range that was stated.
By their numbers in this assay, from the lowest: compound 3; then compounds 4, 2 and 1 (each within the scatter of the next).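

In this assay, the exchange of 3-methylphenyl for 4-chlorophenyl on the amide-type nitrogen reads a number 0.3 percentage points lower from compound 2 to compound 4 (within the scatter), and chloro in place of fluoro on the aromatic carbon reads a number 10 percentage points lower from compound 1 to compound 4 (within the scatter). Where the earlier compounds offered a single exchange at this place, compounds 1, 2 and 4 now form a set of three substituted phenyl groups, all within the scatter of one another, so this assay does not separate them. No measurement shown gives a reason for this result.

On these data alone, all three compounds give readings at a single concentration, so whether they would separate at lower concentrations stays open. Also open, as far as these compounds go, is how this assay would respond to a phenyl ring carrying a carboxylic acid or an amine, or to a cyclohexyl group, on this nitrogen.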